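This account rests on a few compounds, and the source may have more. Where it says the series, first, only, none or still open, it means among the compounds named here.

Working notes on the allylphenol biphenyl series.

Three compounds have numbers in a functional assay on A549 cells (Homo sapiens) for antiproliferative activity, read by MTT assay, with a stated time of 24 h; on this read-out lower numbers stand for stronger inhibition and higher numbers for weaker inhibition. Compound 1 `C=CCc1ccc(OCCC)c(-c2ccc(OCCC)c(CC=C)c2)c1` carries propoxy groups and allyl groups on both rings. In this assay compound 1 gives > 114000 nM, which is a limit of the assay and not a number (the limit of > 114000 nM in this assay, at which 1 of the 3 values shown sits). Compound 2 `C=CCc1cc(-c2cccc(C(F)(F)F)c2)ccc1O` keeps a free phenol and a single allyl group and bears a trifluoromethyl on the second ring; in this assay compound 2 gives 73000 nM. Compound 3 `C=CCc1cc(-c2cccc([N+](=O)[O-])c2)cc(CC=C)c1O` has two allyl groups and a nitro group; in this assay compound 3 gives 80000 nM. The values of compound 2 and compound 3 sit within the usual scatter of one another, so no order between them can be read from these data; compound 1 offers only its limit.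

Compound 4 `C=CCc1cc(-c2ccccc2)ccc1O` has not yet been run. It differs from compound 2 in one place: hydrogen in place of trifluoromethyl on an aromatic carbon. For the measured compounds named here, no pair of measured compounds differing in a single place is available, so the size of this step rests on expectation alone. Given that compound 2 and compound 3 agree within scatter despite different groups on the second ring, the step in this assay is expected to be small, in neither direction beyond the scatter, as a 1.2-fold higher number from compound 2 to compound 4 (0.09 log units; within the scatter). Compound 4 is estimated at 90000 nM, with a range from 40000 nM to 200000 nM, and a real chance that only a limit is reported.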

Compound 4, half-maximal inhibitory concentration: > 100000 nM
Compound 4 was reported as a limit (the forecaster's own chance of this, stated with the estimate: 35%); middle value at least 1.1-fold (0.04 log units) from the limit.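

Replacing trifluoromethyl with hydrogen on an aromatic carbon, meta to a large group, gives the series its first step between compounds that differ in one place, read in this assay as an at least 1.3-fold higher number from compound 2 to compound 4 (0.13 log units; that floor lies within the scatter). Compound 4 stands at a limit of the assay and not at a number: the limit of > 100000 nM in this assay, at which 1 of the 4 values shown sits. As far as these compounds go, the step is therefore only a floor, and because that floor lies within the scatter, these data neither show that trifluoromethyl at this place matters nor rule out a much larger step, so the true size stays unknown in the upward direction.

For the compounds shown here, compound 3 cannot be used to extend this reading, as it differs from compound 2 in more than one place, so the nitro group has no single-place step of its own at this position. From the compounds shown here alone, whether an amine, a carboxylic acid or a longer chain at this place would give a clearly lower number than trifluoromethyl or hydrogen remains open.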